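A few compounds are considered here, and "the series" means these few. Any claim that something is new, unique, unknown or untested is made for them only; others in the source may bear on it.

Measured compounds:
compound 1 `COc1ccc2nc(C)cc(OCC(=O)Nc3cccc(C)c3)c2c1` — 193000 nM
compound 2 `COc1ccc2nc(C)cc(OCC(=O)Nc3cc(C)c(F)c(C)c3)c2c1` — 31500 nM
compound 3 `COc1ccc2nc(C)cc(OCC(=O)Nc3ccc(Cl)cc3Cl)c2c1` — 20500 nM

The shared core carries an amide whose nitrogen bears a ring, and that ring is what changes. In a physicochemical assay for solubility, in phosphate buffer, measured as kinetic solubility, with a stated time of 1 h, at pH 7.4 (on this read-out higher numbers stand for higher solubility and lower numbers for lower solubility), compound 1 gives the high number above, compound 2 gives a lower one, and compound 3 gives the lowest of the three. Among the compounds with values here, compound 3 sits at the low end, though the step of a 1.5-fold lower number from compound 2 to compound 3 (0.19 log units; within the scatter) is within the scatter, so those two cannot be ordered; only the step of a 9.4-fold lower number from compound 1 to compound 3 (0.97 log units; beyond the scatter) is a clear one.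

Compound 4 `COc1ccc2nc(C)cc(OCC(=O)Nc3noc(C)c3C)c2c1` has not been measured. It differs from compound 3 in one place: 4,5-dimethyl-1,2-oxazol-3-yl in place of 2,4-dichlorophenyl on an amide-type nitrogen.

Within the data shown here, two measured steps bear on the comparison, both replacing the ring on the amide nitrogen: the move to a substituted phenyl ring a 6.1-fold lower number from compound 1 to compound 2 (0.79 log units; beyond the scatter) and the move to another such ring a 9.4-fold lower number from compound 1 to compound 3 (0.97 log units; beyond the scatter). Both lowered the number by a modest amount. Compound 4 instead carries a five-membered ring with two hetero atoms, a change unlike either measured step, so the direction rests on the range spanned by compounds 1 to 3 rather than on a matching precedent. The expectation is a rise back toward compound 1, estimated as a 5.4-fold higher number from compound 3 to compound 4 (0.73 log units; beyond the scatter). For compound 4 the expected value in this assay is 110000 nM, with a range from 35000 nM to 350000 nM.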

Compound 4, solubility: 196000 nM
Beside the measured number, compound 4's estimate is 1.8-fold (0.25 log units) below it; low and high end bracket the measured number.
By their numbers in this assay, from the lowest: compounds 3 and 2 (each within the scatter of the next); then compounds 1 and 4 (each within the scatter of the next).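

Until now only substituted phenyl rings had been seen on the amide-type nitrogen, and all of them gave lower numbers than compound 1. In this assay, a five-membered aromatic ring with 2 hetero atoms, 4,5-dimethyl-1,2-oxazol-3-yl, gives a 9.6-fold higher number from compound 3 to compound 4 (0.98 log units; beyond the scatter) and a 6.2-fold higher number from compound 2 to compound 4 (0.79 log units; beyond the scatter), while the step of a 1.0-fold higher number from compound 1 to compound 4 (0.01 log units; within the scatter) leaves those two compounds unordered, so two very different rings share the top of this small set. Nothing measured here explains why the numbers fall this way.

The compounds shown leave open whether the two methyl groups on the 4,5-dimethyl-1,2-oxazol-3-yl ring matter, and how a ring carrying an amine or a carboxylic acid would read. They also leave open what a longer chain on the amide-type nitrogen, in place of the ring, would give.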